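An Added Methoxy on a Flat Series

The compounds below may be only part of what the source reports. "The series", "measured", "known", "first", "only" and "open" are said of these compounds alone.

In a functional assay on RAW264.7 cells (Mus musculus) for inhibition, read by ELISA, with a stated time of 24 h (a higher number here means that more compound is needed for the effect, a lower number that less compound is needed), compound 1 `CC/C=C\C[C@H]1C(=O)C=C[C@H]1CC(=O)OCCC` gives 23000 nM, compound 2 `CC/C=C\C[C@H]1C(=O)C=C[C@H]1CC(=O)Oc1ccccc1` gives 33000 nM and compound 3 `CC/C=C\C[C@H]1C(=O)C=C[C@H]1CC(=O)OC(C)C` gives 20000 nM. Compound 3 thus stands within the scatter of both others. Compound 4 `CC/C=C\C[C@H]1C(=O)C=C[C@H]1CC(=O)OC(C)COC` keeps the shared core and differs from compound 3 as follows: methoxy in place of hydrogen on a saturated chain carbon, two bonds along the chain from an oxygen next to a carbonyl group. That is methoxy in place of hydrogen on a saturated chain carbon, two bonds along the chain from an oxygen next to a carbonyl group. Changes to the group on that oxygen have so far moved this assay little: a 1.2-fold lower number from compound 1 to compound 3 (0.06 log units; within the scatter), a 1.7-fold lower number from compound 2 to compound 3 (0.22 log units; within the scatter) and a 1.4-fold higher number from compound 1 to compound 2 (0.16 log units; within the scatter). No step beyond the scatter is therefore expected, and the estimated step is a 1.1-fold higher number from compound 3 to compound 4 (0.04 log units; within the scatter). Compound 4 is expected near 22000 nM, within an estimated range of 10000 nM to 50000 nM.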

Compound 4, half-maximal effective concentration: 23000 nM
Compound 4: the middle estimate sits 1.0-fold (0.02 log units) below what was measured, within the range that was stated.
By their numbers in this assay, from the lowest: compounds 3, 1, 4 and 2 (each within the scatter of the next).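

The earlier compounds shown here carried only carbon groups on this oxygen; compound 4 adds methoxy, with its hydrogen-bond acceptor, yet this assay shows a 1.2-fold higher number from compound 3 to compound 4 (0.06 log units; within the scatter) for that addition. The comparisons with the other two compounds, a 1.4-fold lower number from compound 2 to compound 4 (0.16 log units; within the scatter) and no change at the digits printed from compound 1 to compound 4 (within the scatter), also stay inside the flat pattern, so this first oxygen-bearing group leaves the series as flat as before. No measurement here explains that flatness.

As far as these compounds go, whether an amine or a carboxylic acid at this position would produce a step beyond the scatter remains open. So does the effect of a longer chain carrying the methoxy.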